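Chloro for methyl on the aryl ring of compound 1

This account rests on a few compounds, and the source may have more. Where it says the series, first, only, none or still open, it means among the compounds named here.

Measured in a functional assay on C6 cells (Rattus norvegicus) for cytotoxicity, read by MTT assay, with a stated time of 24 h, tested at 6 ug/mL; a higher number here means a weaker effect of the compound at the concentration tested, a lower number a stronger effect:
- compound 1 `Cc1ccc(-c2cs/c(=N/NC(=O)CSc3nnnn3-c3ccccc3)n2-c2ccccc2)cc1`: 66.8%
- compound 2 `Cn1cnnc1SCC(=O)N/N=c1/scc(-c2ccc(C#N)cc2)n1-c1ccccc1`: 70.2%
- compound 3 `Cc1nnc(SCC(=O)N/N=c2/scc(-c3ccc(F)cc3)n2-c2ccccc2)s1`: 74.3%

On the numbers shown, compound 1 stands at one end of the three, but compound 2 and compound 3 both lie within the usual scatter of it, so the three cannot be told apart in this assay on this evidence. No pair of these compounds differs in one place only, so no single-change step is available from the measured set.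

The next compound to be measured is compound 4 `O=C(CSc1nnnn1-c1ccccc1)N/N=c1/scc(-c2ccc(Cl)cc2)n1-c1ccccc1`. It differs from compound 1 as follows: chloro in place of methyl on an aromatic carbon. Nothing measured in the series isolates this change, and the three values on hand are indistinguishable within the scatter, so no direction can be read off from them. The step from compound 1 to compound 4 is therefore expected to be small, a number 0.8 percentage points lower from compound 1 to compound 4 (within the scatter), and not beyond the scatter in either direction. For compound 4 in this assay the estimate is 66%, with a range from 52% to 80%.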

Compound 4, a percentage reported as activity, at one concentration (the size of the read-out at that concentration, not a potency): 77.4%
The estimate for compound 4 lay 11.4 percentage points below the measured number; measured number inside the range.
By their numbers in this assay, from the lowest: compounds 1, 2, 3 and 4 (each within the scatter of the next, the first and the last beyond it).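

In this assay, the series now has its first single-change step, 4-methylphenyl to 4-chlorophenyl on an aromatic carbon of the six-membered ring, with a number 10.6 percentage points higher from compound 1 to compound 4 (beyond the scatter) as the result. This shows that the position is not silent to substitution: the higher number reads as a weaker effect at the one concentration tested, which is a read-out size and not a potency. No data on hand account for this step.

With a single pair at this position, an amine, a methoxy group or a carboxylic acid in the same place could fall on either side of this step, so no trend across substituents can be stated. On these data alone, whether the step carries over to the different sulfur-linked groups of compound 2 and compound 3 also remains open.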